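The source may report more compounds than this note shows. Statements on the series, on what has been measured and on what is new or still open speak of the compounds shown alone.

Working notes on the series in a functional assay on HepG2 cells (Homo sapiens) for cytotoxicity; a higher number here means a weaker inhibitor, a lower number a stronger inhibitor.

Compound 1 `N#C/N=C1\N(CCCCCCCOc2ccc(Cl)cc2)C(=O)CN1c1ccncc1` gives 2740 nM in this assay. Compound 2 `CC1C(=O)N(CCCCCCCOc2ccc(Cl)cc2)/C(=N\C#N)N1c1ccncc1` gives 359 nM. Among the compounds with values here, the one single-point step measured so far is a 7.6-fold lower number from compound 1 to compound 2 (0.88 log units; beyond the scatter). Compound 3 `N#C/N=C1\N(CCCCCOc2ccc(Cl)cc2)C(=O)C(c2ccccc2)N1c1ccncc1` gives 415 nM; among the three numbers it stands second highest, with compound 2 nearest, inside the scatter, and compound 1 furthest, beyond the scatter.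

Compound 4 `N#C/N=C1\N(CCCCCCCOc2ccc(Cl)cc2)C(=O)C(c2ccccc2)N1c1ccncc1` is still to be measured in this assay. Relative to compound 3 the change is 2-(4-chlorophenoxy)ethyl in place of 4-chlorophenoxy on a saturated chain carbon, five bonds along the chain from an amide-type nitrogen in a ring. Within the data shown here, no measured pair differs only in this chain length, so none of the steps bears on it directly; the only step known concerns a methyl in place of hydrogen on the saturated ring carbon and says nothing about the chain. With nothing to point either way, the expectation is no step beyond the scatter, that is a 1.0-fold higher number from compound 3 to compound 4 (0.01 log units; within the scatter), and compound 4 is estimated at 420 nM with a range of 150 nM to 1200 nM.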

Compound 4, half-maximal inhibitory concentration: 380 nM
The estimate for compound 4 lay 1.1-fold (0.04 log units) above the measured number; the measured number falls inside the stated range.
By their numbers in this assay, from the lowest: compounds 2, 4 and 3 (each within the scatter of the next); then compound 1.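

In this assay the step of 2-(4-chlorophenoxy)ethyl in place of 4-chlorophenoxy on a saturated chain carbon, five bonds along the chain from an amide-type nitrogen in a ring, is a 1.1-fold lower number from compound 3 to compound 4 (0.04 log units; within the scatter) and so shows no effect of this chain change with phenyl on the saturated ring carbon. With the chain held constant, phenyl in place of hydrogen on that ring carbon gives a 7.2-fold lower number from compound 1 to compound 4 (0.86 log units; beyond the scatter) in size close to the methyl step, and phenyl in place of methyl gives a 1.1-fold higher number from compound 2 to compound 4 (0.02 log units; within the scatter) as the direct comparison of the two groups. Nothing available accounts for these readings.

Going by these compounds, whether the chain change is equally silent with hydrogen or methyl on the ring carbon remains open. Also open, on these data alone, is what an amine or a carboxylic acid on that ring carbon would give, or a still longer chain.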